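The compounds below may be only part of what the source reports. "The series", "measured", "known", "first", "only" and "open" are said of these compounds alone.

Of the compounds shown here, two have been read so far in a functional assay on MCF7 cells (Homo sapiens) for cytotoxicity, read by MTT assay, with a stated time of 48 h (a lower number here means a stronger inhibitor, a higher number a weaker inhibitor), and they lie far apart. Compound 1 `C/C(=N/NC(=S)Nc1ccccc1)c1ccccn1` gives 0.18 nM there, while compound 2 `CC(=NNC(=S)Nc1cccc(I)c1)c1ccccn1` gives 45 nM as the higher of the two numbers, a gap well beyond the usual scatter. Compound 2 is thus the weaker inhibitor of the pair. Compound 3 `CC(=NNC(=S)Nc1ccccc1)c1ccccn1` follows from compound 2 by a single change hydrogen in place of iodo on an aromatic carbon in which hydrogen stands in place of iodo on an aromatic carbon, meta to a large group. Among the compounds with values here, no measured pair shows this change alone, so its size cannot be read directly. However, compound 3 has the same atoms and connections as compound 1, which gives 0.18 nM as the main anchor for the expectation, and it differs only in having no double-bond geometry drawn. A large fall in the number is therefore expected, with an estimated step of a 23-fold lower number from compound 2 to compound 3 (1.35 log units; beyond the scatter) lying beyond the scatter. The estimated value for compound 3 is 2 nM within an expected range from 0.15 nM to 40 nM in this cytotoxicity measurement.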

Compound 3, half-maximal inhibitory concentration: 0.18 nM
For compound 3 the middle estimate is 11-fold (1.05 log units) above the measured one; the measured number falls inside the stated range.
By their numbers in this assay, from the lowest: compounds 1 and 3 (each within the scatter of the next); then compound 2.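

In this assay, putting hydrogen in place of iodo on an aromatic carbon, meta to a large group, gives a 250-fold lower number from compound 2 to compound 3 (2.40 log units; beyond the scatter). Within the data shown here, this is the first step that isolates a change at this place, and it ties a large difference in the numbers to the iodo group alone. The pair sharing the same atoms and bonds shows no change at the digits printed from compound 1 to compound 3 (within the scatter), so in these numbers the Z drawing of the double bond and the drawing without a configuration cannot be told apart, and the structures alone do not settle whether the two entries are separate isomers, the only difference being this: the fact that one of compounds 1 and 3 is drawn with a defined configuration and the other without, at the place where they differ

The compounds shown give only the two ends of this comparison, hydrogen and iodo, so it remains open where a fluoro, chloro, bromo, methyl or methoxy group, or an amine or a carboxylic acid, would fall at this place. From the compounds shown here alone, it also remains open whether iodo on another carbon of the same ring would give a step of similar size, and how the opposite Z or E form of the double bond would read.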